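The compounds below may be only part of what the source reports. "The series", "measured", "known", "first", "only" and "open" are said of these compounds alone.

- Compound 1 (`COc1cccc(NC(=O)c2nnn(Cc3ccc(C(C)C)cc3)c2N)c1`) gives > 50100 nM as a limit
- Compound 2 (`COc1cccc(NC(=O)c2nnn(Cc3ccc(SC)cc3)c2N)c1`) gives > 50100 nM as a limit

In a toxicity assay on Vero cells (Chlorocebus sabaeus) for inhibition (a higher number here means that more compound is needed for the effect, a lower number that less compound is needed), compound 2 stands at > 50100 nM which is a limit and not a number. Both measured compounds sit at the same limit (the limit of > 50100 nM in this assay, at which 2 of the 2 values shown sit). Going by the values given here, the only measured step (a step that the two limits leave unreadable from compound 1 to compound 2) therefore gives no usable size. Compound 3 (`COc1cccc(NC(=O)c2nnn(Cc3ccc(C4CC4)cc3)c2N)c1`) has cyclopropyl in place of methylsulfanyl on an aromatic carbon. No step beyond the scatter can be forecast in this assay and no direction is expected. The expected change (a step that the limit leaves unreadable from compound 2 to compound 3) is correspondingly uncertain. The estimate for compound 3 is 55000 nM with an expected range from 25000 nM to 100000 nM and the result may well be only a limit.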

Compound 3, half-maximal effective concentration: > 50100 nM
Compound 3 ended at the assay's limit (the forecaster's own chance of this, stated with the estimate: 85%); the middle value lies beyond the limit too.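

Going by these compounds alone, compound 1, compound 2 and compound 3 all end at the same limit, so no step between them can be read: the limit of > 50100 nM in this assay, at which 3 of the 3 values shown sit. On these data alone, whether isopropyl, methylsulfanyl and cyclopropyl differ at all in this assay stays open.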